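The source may hold more compounds than are shown below. What is called first, only, known or untested is meant among the compounds shown, and "the series" means these compounds.

Measured compounds:
- compound 1, `CCOc1cccc(C(CC)c2ccc(O)c(OC)c2)c1O`: 77%
- compound 2, `CCC(c1ccc(O)c(OC)c1)c1ccc(O)cc1O`: 75%

In a functional assay for inhibition, with a stated time of 12 h, tested at 100 ug/mL (on this read-out lower numbers stand for less inhibition and higher numbers for more inhibition at the one concentration tested (going by the name of the read-out)), compound 1 gives 77%. Compound 2 gives 75% in this assay. The two values lie within the scatter of each other, so compound 1 cannot be set apart from compound 2 on these numbers; both sit at a similar level of inhibition. Among the compounds with values here, no pair of measured compounds differs in one place, so no single-change step is available from which to judge how sensitive this assay is to changes on the ring carrying the hydroxy group.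

Compound 3, `CCC(c1ccc(O)c(OC)c1)c1cccc(C(C)C)c1O`, is not yet measured. It differs from compound 1 as follows: isopropyl in place of ethoxy on an aromatic carbon. With two measured compounds at a similar level despite different substitution, the expectation is that compound 3 stays near compound 1 in this assay, with no step beyond the scatter, and the step from compound 1 to compound 3 is estimated at a number 5 percentage points lower from compound 1 to compound 3 (within the scatter). Compound 3 is expected to give 72% in this assay, within a range of 52% to 88%.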

Compound 3, a percentage reported as inhibition, at one concentration (the size of the read-out at that concentration, not a potency): 78%
Compound 3: middle estimate off by 6 percentage points, on the low side; low and high end bracket the measured number.
By their numbers in this assay, from the lowest: compounds 2, 1 and 3 (each within the scatter of the next).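

Isopropyl in place of ethoxy on an aromatic carbon, ortho to a hydroxy group, reads in this assay as a number 1 percentage points higher from compound 1 to compound 3 (within the scatter) and gives the series its first single-change step. Isopropyl carries no hydrogen-bond acceptor and ethoxy does, yet at the one concentration tested the read-out does not separate these two groups at this position. No measurement on hand bears on why the two groups read alike.

From the compounds shown here alone, whether an amine, a carboxylic acid or a longer chain at this position would stay at the same level remains open, as the two groups compared here are of equal heavy-atom size. Going by these compounds, whether compound 1 and compound 3 would also match across a range of concentrations also remains open, since a single-concentration read-out is not a potency.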